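Adding a hydroxy group to compound 1

The source may report more compounds than this note shows. Statements on the series, on what has been measured and on what is new or still open speak of the compounds shown alone.

Measured compounds:
Compound 1 `COc1ccc(C2=C(c3cc(OC)c(OC)c(OC)c3)C(=O)CC2O[SiH2]C(C)(C)C)cc1`: > 100 ug/mL
Compound 2 `COc1ccc(C2=C(c3cc(OC)c(OC)c(OC)c3)C(=O)C(O)C2)cc1F`: < 1 ug/mL

In an ADME assay on HT-29 cells (Homo sapiens) for cytotoxicity, read by MTT assay, with a stated time of 72 h (a higher number here means a weaker inhibitor, a lower number a stronger inhibitor), compound 1 gives > 100 ug/mL, which is a limit and not a number. Compound 2 gives < 1 ug/mL, which is also a limit. Within the data shown here, of these two values, compound 1 holds the one at the high-number end, and no measured step connects them.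

Compound 3 `COc1ccc(C2=C(c3cc(OC)c(OC)c(OC)c3)C(=O)CC2O[SiH2]C(C)(C)C)cc1O` has hydroxy in place of hydrogen on an aromatic carbon, going from 4-methoxyphenyl to 3-hydroxy-4-methoxyphenyl (hydroxy in place of hydrogen on an aromatic carbon). A move toward stronger inhibition is expected, though its size is uncertain, with an estimated at least 12-fold lower number from compound 1 to compound 3 (1.09 log units; beyond the scatter). For compound 3 the expected value is 8 ug/mL, with an estimated range of 0.5 ug/mL to 100 ug/mL.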

Compound 3, half-maximal inhibitory concentration: 38 ug/mL
Compound 3: the middle estimate sits 4.8-fold (0.68 log units) below what was measured; low and high end bracket the measured number.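

In this assay, hydroxy on this aromatic carbon, ortho to a methoxy group, gives an at least 2.6-fold lower number from compound 1 to compound 3 (0.42 log units; beyond the scatter). Compound 3 gives 38 ug/mL, a measured number, so this single change brings the core of compound 1 into the range the assay can read. Compound 1 stands at a limit and not a number, so the step gives only a minimum size: the limit of > 100 ug/mL in this assay, at which 1 of the 3 values shown sits. Going by these compounds, whether an amine or a carboxylic acid on the same carbon would give a similar step remains open. Compound 2 differs from compound 3 in more than one place, so it does not show what hydroxy contributes here.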